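The source may report more compounds than this note shows. Statements on the series, on what has been measured and on what is new or still open speak of the compounds shown alone.

Measured so far in an ADME assay on MT4 cells (Homo sapiens) for cytotoxicity, read by MTT assay, with a stated time of 4 days; a higher number here means that more compound is tolerated, a lower number that less compound is tolerated:
Compound 1, `Cc1cc(C)cc(Cn2c(=O)cc(N=[N+]=[N-])n(Cc3ccccn3)c2=O)c1`: compound 1 gives > 100000 nM, a limit of the assay.
Compound 2, `Cc1cc(C)cc(Cn2c(=O)cc(N)n(Cc3ccncc3)c2=O)c1`: compound 2 gives > 100000 nM, a limit of the assay.

Compound 2 stands only at a limit in this assay, with no number known for it. The other value shown is a limit as well, so both sit at the same point: the limit of > 100000 nM in this assay, at which 2 of the 2 values shown sit. Going by the values given here, no two measured compounds differ in one place, so no measured step exists.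

Compound 3, `Cc1cc(C)cc(Cn2c(=O)cc(N=[N+]=[N-])n(Cc3ccncc3)c2=O)c1`, is not yet measured. From compound 2 to compound 3 the change is azido in place of amino on an aromatic carbon. The azido group is already present in compound 1, which sits at the limit. The step this estimate means, a step that the limit leaves unreadable from compound 2 to compound 3, is expected to be none beyond the scatter. For compound 3 the estimate is 150000 nM, within 80000 nM to 400000 nM, and most likely reported again only as a limit.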

Compound 3, half-maximal cytotoxic concentration: 59000 nM
Compound 3: middle estimate off by 2.5-fold (0.41 log units), on the high side; the measured number lies below the stated range.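

In this assay, going by these compounds alone, compound 3 gives 59000 nM, the first value that is a number and not a limit, and it carries azido on this aromatic carbon together with the pyridin-4-yl group. Azido in place of amino gives an at least 1.6-fold lower number from compound 2 to compound 3 (0.22 log units; that floor lies within the scatter), and pyridin-4-yl in place of pyridin-2-yl gives an at least 1.6-fold lower number from compound 1 to compound 3 (0.22 log units; that floor lies within the scatter), so each change is known only as a floor. The full size of neither step can be read, because both partners of compound 3 stand at a limit: the limit of > 100000 nM in this assay, at which 2 of the 3 values shown sit.

On these data alone, whether the azido group, the pyridin-4-yl group or the pairing of the two sets the number for compound 3 remains open. Also open, as far as these compounds go, is how a nitrile or a methoxy group on this aromatic carbon would read in this assay.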